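From 4-acetylphenyl to 3-hydroxy-4-methoxyphenyl on a shared core

A few compounds are considered here, and "the series" means these few. Any claim that something is new, unique, unknown or untested is made for them only; others in the source may bear on it.

Measured in a functional assay on A549 cells (Homo sapiens) for antiproliferative activity, read by MTT assay, with a stated time of 72 h (on this read-out higher numbers stand for weaker inhibition and lower numbers for stronger inhibition), so far:
- compound 1 `COc1ccccc1-c1ccc2ncn(-c3cc(OC)c(OC)c(OC)c3)c2c1` gives 4320 nM as its value
- compound 2 `COc1cc(-n2cnc3ccc(-c4ccc(C(C)=O)cc4)cc32)cc(OC)c1OC` gives 2510 nM as its value

Among the measured compounds shown here, compound 2 lies within the scatter of compound 1, and the only measured step is a 1.7-fold lower number from compound 1 to compound 2 (0.24 log units; within the scatter) at the same place. Compound 3 `COc1ccc(-c2ccc3ncn(-c4cc(OC)c(OC)c(OC)c4)c3c2)cc1O` carries 3-hydroxy-4-methoxyphenyl in place of 4-acetylphenyl on an aromatic carbon. That single step is thin evidence, and neither measured compound has the hydroxy group, so only a loose expectation is possible in this assay here. The expected change, toward a lower number and beyond the scatter, is a 6.3-fold lower number from compound 2 to compound 3 (0.80 log units; beyond the scatter) as estimated. For compound 3 the estimate is 400 nM, with an expected range of 30 nM to 3000 nM.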

Compound 3, half-maximal inhibitory concentration: 200 nM
Estimate against measurement, compound 3: 2.0-fold (0.30 log units) above, within the range that was stated.
By their numbers in this assay, from the lowest: compound 3; then compounds 2 and 1 (each within the scatter of the next).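

In this assay, the group on this aromatic carbon turns out to matter strongly, which the first two compounds, within the scatter of each other, did not show: 3-hydroxy-4-methoxyphenyl gives a 13-fold lower number from compound 2 to compound 3 (1.10 log units; beyond the scatter) and a 22-fold lower number from compound 1 to compound 3 (1.33 log units; beyond the scatter). Of the three compounds, only compound 3 carries a hydrogen-bond donor in this group. Nothing available explains why this change has so large an effect. Going by these compounds, it remains open whether the hydroxy group itself carries the step, and whether an amine or a carboxylic acid in its place would do the same.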